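The compounds below may be only part of what the source reports. "The series", "measured", "known", "first", "only" and "open" are said of these compounds alone.

Measured compounds:
compound 1, `O=S(=O)(c1cccc2ccccc12)n1ccc2ccc(N3CCN4CCCCC4C3)cc21`: 1.7 nM
compound 2, `O=S(=O)(c1ccc(F)cc1F)n1ccc2ccc(N3CCN4CCCCC4C3)cc21`: 3.6 nM

Within the data shown here, only two compounds have numbers in an assay on HEK293 cells for displacement of a labelled ligand from 5-hydroxytryptamine receptor 6 (Homo sapiens); on this read-out higher numbers stand for weaker inhibition and lower numbers for stronger inhibition. Compound 2 has the higher of the two, weaker than compound 1 by a 2.1-fold higher number from compound 1 to compound 2 (0.33 log units; beyond the scatter), the change there being naphthalen-1-yl replaced by 2,4-difluorophenyl on the sulfonyl sulfur. Compound 3, `O=S(=O)(c1ccccc1)n1ccc2ccc(N3CCN4CCCCC4C3)cc21`, has not yet been measured in this assay. It differs from compound 2 by phenyl in place of 2,4-difluorophenyl on a sulfonyl sulfur. Among the measured compounds shown here, only the step from compound 1 to compound 2 bears on the sulfonyl group, and it was modest; no measured pair shows what the two fluorine atoms alone contribute. A step no larger than the usual scatter is therefore expected from compound 2 to compound 3, in either direction, with a slight lean toward a higher number. Compound 3 is estimated to give 4.5 nM in this assay, with a range from 1.5 nM to 13 nM, meaning an expected step of a 1.3-fold higher number from compound 2 to compound 3 (0.10 log units; within the scatter).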

Compound 3, inhibition constant: 5.7 nM
Beside the measured number, compound 3's estimate is 1.3-fold (0.10 log units) below it, and the stated range covers the measured number.
By their numbers in this assay, from the lowest: compound 1; then compounds 2 and 3 (each within the scatter of the next).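

In this assay, the step that isolates the two fluorine atoms on the ring at the sulfonyl sulfur is a 1.6-fold higher number from compound 2 to compound 3 (0.20 log units; within the scatter), so on these compounds their contribution cannot be told apart from the scatter. The step for phenyl in place of naphthalen-1-yl is a 3.4-fold higher number from compound 1 to compound 3 (0.53 log units; beyond the scatter), so compound 1 stands apart from both compound 2 and compound 3, and at this position the clear difference lies between naphthalen-1-yl and the two single-ring groups, not between those two groups themselves. No supporting information bears on why the numbers fall this way.

Going by these compounds, it remains open whether a single fluorine would behave like the pair. On these data alone, it is also open how this position would respond to a benzyl group or a pyridyl ring on the sulfonyl sulfur, or to an amine carried on the phenyl.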